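The source may report more compounds than this note shows. Statements on the series, on what has been measured and on what is new or still open speak of the compounds shown alone.

Measured so far in a functional assay on COLO 205 cells (Homo sapiens) for cytotoxicity, read by sulforhodamine B assay, with a stated time of 48 h, tested at 10 uM; on this read-out lower numbers stand for a stronger effect and higher numbers for a weaker effect at the one concentration tested:
compound 1 `COc1cc(-c2cc(/C=C/C(=O)c3ccc(N)cc3)[nH]n2)cc(OC)c1OC` gives -84%.
compound 2 `COc1ccc(C(=O)/C=C/c2cc(-c3cc(OC)c(OC)c(OC)c3)n[nH]2)cc1OC` gives -93%.
compound 3 `COc1ccc(C(=O)/C=C/c2cc(-c3cc(OC)c(OC)c(OC)c3)n[nH]2)cc1` gives -90%.

On the numbers alone compound 1 holds the highest figure of the three, yet neither step away from it leaves the scatter: the nearest is a number 6 percentage points lower from compound 1 to compound 3 (within the scatter) and the furthest is a number 9 percentage points lower from compound 1 to compound 2 (within the scatter). The remaining pair behaves the same way, a number 3 percentage points higher from compound 2 to compound 3 (within the scatter), so the three measured compounds are not told apart in this assay.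

Compound 4 `COc1cc(-c2cc(/C=C/C(=O)c3ccc(F)c(F)c3)[nH]n2)cc(OC)c1OC` is the next member. It differs from compound 1 as follows: 3,4-difluorophenyl in place of 4-aminophenyl on a carbonyl carbon.

For the measured compounds named here, two measured steps bear on this change. The step of a number 9 percentage points lower from compound 1 to compound 2 (within the scatter) swaps the same group on the same carbonyl carbon for another substituted phenyl, and the step of a number 6 percentage points lower from compound 1 to compound 3 (within the scatter) alters the amino group on the aromatic carbon; both stayed within the scatter. Nothing measured here separates one aryl on that carbonyl carbon from another, so the expectation is a step of a number 2 percentage points lower from compound 1 to compound 4 (within the scatter), that is, no change beyond the scatter in either direction.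

Compound 4 is therefore estimated at -86% in this assay, with an expected range from -96% to -70%.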

Compound 4, a percentage reported as activity, at one concentration (the size of the read-out at that concentration, not a potency): -90%
Estimate against measurement, compound 4: 4 percentage points above; measured number inside the range.
By their numbers in this assay, from the lowest: compounds 2, 3, 4 and 1 (each within the scatter of the next).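

Working notes on the aryl on the carbonyl carbon: in this assay, replacing 4-aminophenyl with 3,4-difluorophenyl removes the nitrogen, brings in fluorine and takes the hydrogen-bond donor and acceptor counts of the group to zero, yet the result is a number 6 percentage points lower from compound 1 to compound 4 (within the scatter). The fluorinated aryl is also not told apart from the two methoxylated aryls, with no change at the digits printed from compound 3 to compound 4 (within the scatter) and a number 3 percentage points higher from compound 2 to compound 4 (within the scatter), so all four aryl groups now shown at this carbonyl carbon fall within the scatter of one another, and none of the listed compounds goes against this. No experimental evidence is available that bears on this result.

With a single tested concentration and all four compounds within the scatter, these figures give no potency order for the series. From the compounds shown here alone, it remains open whether a carboxylic acid on the phenyl ring, or a longer alkyl chain in place of the aryl on the carbonyl carbon, would produce a step beyond the scatter in this assay.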